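The source may hold more compounds than are shown below. What is called first, only, known or untested is meant among the compounds shown, and "the series" means these compounds.

Compound 2 `O=c1c(CSC(=S)N2CCOCC2)coc2cc(Cl)ccc12` is one of two compounds with a number in a functional assay on HEp-2 cells (Homo sapiens) for antiproliferative activity, read by MTT assay, with a stated time of 72 h; a higher number here means a weaker inhibitor, a lower number a stronger inhibitor. In this assay compound 2 gives 900 nM. Its nearest companion is compound 1 `Cc1ccc2c(=O)c(CSC(=S)N3CCCCC3)coc2c1`, which carries piperidin-1-yl on the thiocarbonyl carbon and a methyl on the core; in this assay compound 1 gives 900 nM. The two values stand level at the digits shown, within the scatter of the measurement, so neither can be called stronger.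

Compound 3 `O=c1c(CSC(=S)N2CCCCC2)coc2cc(Cl)ccc12` has not yet been measured. It keeps the chlorine-bearing core of compound 2 and differs in one place: piperidin-1-yl in place of morpholin-4-yl on a thiocarbonyl carbon. Within the data shown here, no measured pair isolates this swap, so its effect is not known from these compounds. Because compound 1 gives 900 nM with the same piperidin-1-yl group, a step from compound 2 to compound 3 of no change at the digits printed from compound 2 to compound 3 (within the scatter) is expected, that is, no change beyond the scatter. For compound 3 the estimate is 900 nM, with a range from 400 nM to 2000 nM.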

Compound 3, half-maximal inhibitory concentration: 280 nM
For compound 3 the middle estimate is 3.2-fold (0.51 log units) above the measured one; measured number outside the range, below it.
By their numbers in this assay, from the lowest: compound 3; then compounds 1 and 2 (each within the scatter of the next).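

In this assay, the group on the thiocarbonyl carbon turns out to matter: with the chlorine-bearing core held fixed, piperidin-1-yl in place of morpholin-4-yl gives a 3.2-fold lower number from compound 2 to compound 3 (0.51 log units; beyond the scatter). The core matters as well: with piperidin-1-yl kept, chloro in place of methyl on an aromatic carbon gives a 3.2-fold lower number from compound 1 to compound 3 (0.51 log units; beyond the scatter). The level values of compound 1 and compound 2 therefore say nothing about either change alone, for these two compounds differ in both places at once.

No measurement shown here explains either step. Still open, from the compounds shown here alone, is how other groups on the thiocarbonyl carbon, such as pyrrolidin-1-yl or an open-chain diethylamino group, or a bromo or fluoro in place of chloro, would fare in this assay.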